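The source may report more compounds than this note shows. Statements on the series, on what has been measured and on what is new or still open speak of the compounds shown alone.

Series notes. Of the compounds shown here, three of the shared core have been measured, each with a different aryl group on the chain. Compound 1 `CN(C)Cc1cc(C(=O)/C=C/c2ccc(Cl)cc2Cl)cc(CN(C)C)c1O` gives 3090 nM in a functional assay on cells (Tumor Cell line, Homo sapiens) for cytotoxicity; on this read-out higher numbers stand for weaker inhibition and lower numbers for stronger inhibition. Compound 2 `CN(C)Cc1cc(C(=O)/C=C/c2c(Cl)cccc2Cl)cc(CN(C)C)c1O` gives 5880 nM in this assay, and compound 3 `CN(C)Cc1cc(C(=O)/C=C/c2ccc(Br)cc2)cc(CN(C)C)c1O` gives 6310 nM in this assay. Within the data shown here, compound 3 holds the highest of the three numbers; its gap to compound 2 lies within the scatter, while a 2.0-fold higher number from compound 1 to compound 3 (0.31 log units; beyond the scatter) is beyond it, so only the step from compound 1 separates it clearly.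

The next compound, compound 4 `CN(C)Cc1cc(C(=O)/C=C/c2ccc([N+](=O)[O-])cc2)cc(CN(C)C)c1O`, differs from compound 3 by nitro in place of bromo on an aromatic carbon. Among the measured compounds shown here, no measured step exchanges a halogen for a nitro group, so none bears on this change directly; the steps that touch the same aryl position are a 1.9-fold higher number from compound 1 to compound 2 (0.28 log units; within the scatter), a 2.0-fold higher number from compound 1 to compound 3 (0.31 log units; beyond the scatter) and a 1.1-fold higher number from compound 2 to compound 3 (0.03 log units; within the scatter), all small. On that basis the step in this assay is expected to be small, a 1.1-fold lower number from compound 3 to compound 4 (0.02 log units; within the scatter), with no direction favoured. Compound 4 is therefore estimated at 6000 nM, with a range of 2500 nM to 14000 nM.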

Compound 4, half-maximal inhibitory concentration: 8910 nM
For compound 4 the middle estimate is 1.5-fold (0.17 log units) below the measured one; measured number inside the range.
By their numbers in this assay, from the lowest: compounds 1, 2, 3 and 4 (each within the scatter of the next, the first and the last beyond it).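

Nitro in place of bromo, para to a large group, gives a 1.4-fold higher number from compound 3 to compound 4 (0.15 log units; within the scatter) in this assay so this position carries the larger nitro group of three heavy atoms, with two hydrogen-bond acceptors, without a step beyond the scatter from the bromo compound. Among these compounds, the 4-nitrophenyl group also shows a 1.5-fold higher number from compound 2 to compound 4 (0.18 log units; within the scatter) and, with a 2.9-fold higher number from compound 1 to compound 4 (0.46 log units; beyond the scatter) as the widest step so far, it is separated clearly only from the 2,4-dichlorophenyl group. Nothing on hand accounts for these steps.

Going by these compounds, whether an amine or a carboxylic acid on this aromatic carbon would stay within the scatter of bromo and nitro remains open. So does whether a step from the 4-bromophenyl group to the 4-chlorophenyl group would tell single substitution from double substitution on this ring.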